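Adding a Second Fluorine to a Pyrazolone Amide Series

The compounds below may be only part of what the source reports. "The series", "measured", "known", "first", "only" and "open" are said of these compounds alone.

Measured compounds:
- Compound 1, `Cc1cc(=O)n(-c2ccccc2OC(F)(F)F)nc1C(=O)Nc1ccc(Oc2ncnc3ccsc23)cc1`: 10100 nM
- Compound 2, `Cc1cc(=O)n(-c2ccccc2OC(F)(F)F)nc1C(=O)Nc1ccc(Oc2ncnc3ccsc23)c(F)c1`: 5720 nM
- Compound 3, `Cc1cc(=O)n(-c2ccc(F)cc2)nc1C(=O)Nc1ccc(Oc2ncnc3sccc23)c(F)c1`: 2620 nM

These three compounds were tested in a functional assay on A549 cells (Homo sapiens) for cytotoxicity, read by MTT assay, with a stated time of 72 h; a higher number here means a weaker inhibitor, a lower number a stronger inhibitor. Compound 1 and compound 2 share a core and differ only by fluoro in place of hydrogen on an aromatic carbon; the step of a 1.8-fold lower number from compound 1 to compound 2 (0.25 log units; within the scatter). Compound 3 has a different core from compound 1; the difference between the two cores is not broken down here, and the two values simply show compound 3 with the lower number of the two.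

Compound 4, `Cc1cc(=O)n(-c2ccc(F)c(F)c2)nc1C(=O)Nc1ccc(Oc2ncnc3sccc23)c(F)c1`, is not yet measured. It is made from compound 3 by fluoro in place of hydrogen on an aromatic carbon, the same kind of change as from compound 1 to compound 2, though the surroundings differ: in compound 2 the new fluoro sits ortho to a large group, while in compound 4 it sits ortho to a fluoro group. On the strength of the earlier step of a 1.8-fold lower number from compound 1 to compound 2 (0.25 log units; within the scatter), a step of similar small size is expected for compound 4, a 1.3-fold lower number from compound 3 to compound 4 (0.12 log units; within the scatter). Compound 4 is therefore estimated at 2000 nM, most likely between 900 nM and 4500 nM.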

Compound 4, half-maximal inhibitory concentration: 15700 nM
The estimate for compound 4 lay 7.9-fold (0.89 log units) below the measured number; measured number above the stated range.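

In this assay, going from 4-fluorophenyl to 3,4-difluorophenyl gives a 6.0-fold higher number from compound 3 to compound 4 (0.78 log units; beyond the scatter), so the added fluoro leaves a weaker inhibitor here. Going by these compounds alone, the same exchange of hydrogen for fluoro therefore did not carry over with the same result from one core to the other: the same change on two cores in this assay, a 1.8-fold lower number (0.25 log units; within the scatter) from compound 1 to compound 2 and a 6.0-fold higher number (0.78 log units; beyond the scatter) from compound 3 to compound 4, 11-fold (1.02 log units) apart, beyond the scatter of two such steps This shows that the outcome of this change depends on its surroundings, but it rests on only two steps, and the two starting compounds differ in more than one place, so it does not show which of those differences matters or how the change would behave on any further core.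

The compounds shown leave open whether another group in the same place on the ring, such as a chloro, a methoxy or an amine, would be tolerated better than this fluoro. They also leave open whether the 3,4-difluorophenyl group would give a similar result on the core of compound 1.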